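Carbonyl substituent change from compound 3 to compound 4

The compounds below may be only part of what the source reports. "The series", "measured", "known", "first", "only" and "open" are said of these compounds alone.

Compound 3 `O=C(c1ccccc1F)N1CC(c2nc(-c3cccc(Cl)c3)no2)C1` gives in an assay on HEK293 cells for positive allosteric modulation of metabotropic glutamate receptor 5 (Homo sapiens), read by FLIPR (on this read-out lower numbers stand for an effect already at smaller amounts and higher numbers for an effect only at larger amounts of compound), a value of > 10000 nM, which is a limit of the assay and not a number. Compound 1 `CC1CCN(C(=O)N2CC(c3nc(-c4cccc(Cl)c4)no3)C2)C1` likewise sits at a limit, > 10000 nM. Compound 2 `O=C(N1CCCCCC1)N1CC(c2nc(-c3cccc(Cl)c3)no2)C1` gives 47 nM in this assay. Compound 3 thus sits at the limit, far from the active compound 2.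

Compound 4 `COC1CCCN(C(=O)N2CC(c3nc(-c4cccc(Cl)c4)no3)C2)C1` differs from compound 3 in one place: 3-methoxypiperidin-1-yl in place of 2-fluorophenyl on a carbonyl carbon. The group that enters is a saturated amine ring on the carbonyl carbon, as in compound 1 and compound 2, whereas compound 3 carries an aromatic ring there.

Within the data shown here, two measured steps bear on the change. an at least 210-fold higher number from compound 2 to compound 3 (2.32 log units; beyond the scatter) shows a heavy loss when azepan-1-yl gives way to 2-fluorophenyl; going back to a saturated amine ring points the other way. Yet an at least 210-fold lower number from compound 1 to compound 2 (2.32 log units; beyond the scatter) shows that a saturated ring alone does not settle the matter: compound 1 with 3-methylpyrrolidin-1-yl stays at the limit while azepan-1-yl is active. The 3-methoxypiperidin-1-yl ring is six-membered, between these two cases, and carries a methoxy that neither measured ring has. A lower number is therefore expected for compound 4 than for compound 3, an at least 6.6-fold lower number from compound 3 to compound 4 (0.82 log units; beyond the scatter), with wide uncertainty. Compound 4 is estimated at 1500 nM in this assay, between 200 nM and 10000 nM.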

Compound 4, half-maximal effective concentration: > 10000 nM
Compound 4 gave a limit, no number; the forecaster's own chance of this, stated with the estimate: 35%; middle value at least 6.6-fold (0.82 log units) from the limit.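

In this assay, 3-methoxypiperidin-1-yl in place of azepan-1-yl on a carbonyl carbon gives an at least 210-fold higher number from compound 2 to compound 4 (2.32 log units; beyond the scatter), so a six-membered non-aromatic amine ring carrying a methoxy does not keep the activity seen with azepan-1-yl. With compound 4, a non-aromatic amine ring on the carbonyl carbon has now failed to give a number twice, as in compound 1, which leaves compound 2 as the only compound shown with a measured value and azepan-1-yl as the only group shown to give one: the limit of > 10000 nM in this assay, at which 3 of the 4 values shown sit. The steps among compound 1, compound 3 and compound 4 cannot be read, as each joins two limits, so no order can be given among these three compounds.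

The compounds shown do not separate the ring from its methoxy, and unsubstituted piperidin-1-yl on the carbonyl carbon would be the direct test of whether the six-membered ring or the methoxy goes with the loss. On these data alone, it also remains open whether activity extends beyond azepan-1-yl itself, for example to azocan-1-yl or to an azepan-1-yl ring bearing a methyl.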